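The source may hold more compounds than are shown below. What is called first, only, known or untested is meant among the compounds shown, and "the series" means these compounds.

In a functional assay on OVCAR-5 cells (Homo sapiens) for antiproliferative activity, read by sulforhodamine B assay, with a stated time of 48 h (on this read-out lower numbers stand for stronger inhibition of growth and higher numbers for weaker inhibition of growth), two compounds sharing one core have been measured so far: compound 1 (`O=C(NCCCNc1cc(-c2cn(-c3ccccc3)nc2-c2cccc(O)c2)ccn1)Nc1ccc(F)cc1`) gives 9120 nM and compound 2 (`O=C(NCCCNc1cc(-c2cn(-c3ccccc3)nc2-c2cccc(O)c2)ccn1)Nc1cccc(C(F)(F)F)c1`) gives 9710 nM. Going by the values given here, compound 1 therefore stands level with compound 2, and only this one comparison places it. Among the compounds with values here, the single measured step, a 1.1-fold higher number from compound 1 to compound 2 (0.03 log units; within the scatter), puts 3-(trifluoromethyl)phenyl in place of 4-fluorophenyl on an amide-type nitrogen. Compound 3 (`COc1cccc(-c2nn(-c3ccccc3)cc2-c2ccnc(NCCCNC(=O)Nc3ccc(F)cc3)c2)c1`) keeps the 4-fluorophenyl of compound 1 and differs at another place: methyl in place of hydrogen on an oxygen on an aromatic ring. Compound 3 thus carries 3-methoxyphenyl where compound 1 carries 3-hydroxyphenyl. Within the data shown here, no measured pair tests this change directly, so the step to compound 2 is only a loose guide, and it lies within the scatter. Starting from compound 1 at 9120 nM, no shift beyond the scatter is expected in this assay, and the data favour no direction. The expected change is a 1.1-fold higher number from compound 1 to compound 3 (0.04 log units; within the scatter). For compound 3 the estimate is 10000 nM, with an expected range from 4000 nM to 28000 nM.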

Compound 3, concentration for total growth inhibition: > 37000 nM
Compound 3 ended at the assay's limit; the forecaster's own chance of this, stated with the estimate: 15%; middle value at least 3.7-fold (0.56 log units) from the limit.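

In this assay, the only earlier step, a 1.1-fold higher number from compound 1 to compound 2 (0.03 log units; within the scatter), concerned the group on an amide-type nitrogen and stayed within the scatter, so the compounds had not yet shown any change that moved the read-out. Methyl in place of hydrogen on the oxygen on the aromatic ring gives an at least 4.0-fold higher number from compound 1 to compound 3 (0.60 log units; beyond the scatter), which makes this the first position in the series where a single change reaches beyond the scatter, and the change weakens growth inhibition even though it adds only one carbon. The size of this step has only a lower bound, since the value for compound 3, > 37000 nM, is a limit of the assay and not a number: the limit of > 37000 nM in this assay, at which 1 of the 3 values shown sits.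

The compounds shown leave open whether the loss follows from removing the hydrogen on that oxygen or from adding the methyl, a question that an amine or a fluorine in place of the hydroxy group, or a longer chain such as ethoxy, would help to separate. They also leave open whether the same change has a similar effect when the 3-(trifluoromethyl)phenyl group of compound 2 is present.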